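A few compounds are considered here, and "the series" means these few. Any claim that something is new, unique, unknown or untested is made for them only; others in the source may bear on it.

Measured compounds:
- compound 1, `CCc1nc(-c2ccc(Cl)cc2Cl)c(CC)nc1NC(COC)COC`: 224 nM
- compound 2, `CCc1nc(-c2ccc(OC(F)F)cc2Cl)c(OC)nc1NC(CC)CC`: 2.5 nM
- compound 3, `CCc1nc(-c2ccc(C)cc2OC)c(CC)nc1NC(CC)CC`: 23.7 nM

In an assay on IMR-32 cells for displacement of a labelled ligand from corticotropin-releasing factor receptor 1 (Homo sapiens), read by scintillation counting, with a stated time of 2 h (on this read-out lower numbers stand for stronger inhibition and higher numbers for weaker inhibition), compound 1 gives the highest of the three numbers. Compound 3 gives a number clearly lower than that of compound 1, and compound 2 gives the lowest number of the three, the gap to compound 1 being the largest shown. Both compound 2 and compound 3 carry a (pentan-3-yl)amino group on the shared core, whereas compound 1 carries a (2-methoxy-1-(methoxymethyl)ethyl)amino group there.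

The unmeasured compound 4, `CCc1nc(-c2ccc(Cl)cc2Cl)c(CC)nc1NC(CC)CC`, keeps the core and the dichlorophenyl part of compound 1 and differs from it in one place: pentan-3-yl in place of 2-methoxy-1-(methoxymethyl)ethyl on a nitrogen on an aromatic ring. For the measured compounds named here, no direct step between two measured compounds for this change exists, so the expectation rests on compound 2 and compound 3, both of which carry the entering group and both of which give lower numbers than compound 1. Compound 4 is therefore expected to give a lower number than compound 1, by a step of a 9.0-fold lower number from compound 1 to compound 4 (0.95 log units; beyond the scatter), beyond the usual scatter. For compound 4 the estimated value in this assay is 25 nM, with a likely range from 6 nM to 100 nM.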

Compound 4, inhibition constant: 4.1 nM
Estimate against measurement, compound 4: 6.1-fold (0.79 log units) above; the whole stated range lies above it.
By their numbers in this assay, from the lowest: compounds 2 and 4 (each within the scatter of the next); then compound 3; then compound 1.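

In this assay, replacing 2-methoxy-1-(methoxymethyl)ethyl with pentan-3-yl on a nitrogen on an aromatic ring gives a 55-fold lower number from compound 1 to compound 4 (1.74 log units; beyond the scatter) with the rest of the structure unchanged. The earlier compounds shown here could not show this, as the two groups appeared only on compounds that also differed elsewhere; this pair shows that the change at this position alone produces a large step. Nothing shown accounts for the size of this step.

The compounds shown leave open whether a 1-methoxybutan-2-yl group, which would keep just one methoxy group, would give a number nearer that of compound 1 or that of compound 4. They also leave open whether a larger group on the same nitrogen, such as heptan-4-yl or cyclopentyl, would keep the number as low as that of compound 4.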